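This account rests on a few compounds, and the source may have more. Where it says the series, first, only, none or still open, it means among the compounds named here.

Compound 1 `CC1=C(C(=O)Nc2ccc(F)cc2)C(c2ccc([N+](=O)[O-])cc2)N=C(SCc2ccccc2Cl)N1` and compound 2 `CC1=C(C(=O)Nc2ccc(F)cc2)C(c2ccc([N+](=O)[O-])cc2)N=C(SCc2cccc(Cl)c2)N1` are built on the same core and differ in a single place: 3-chlorophenyl in place of 2-chlorophenyl on a saturated chain carbon bound to a sulfur. In a functional assay on the whole organism (artery, strain albino) with Rattus norvegicus as the target, with a stated time of 240 min, at a dose of 10 mg/kg by the oral route (on this read-out lower numbers stand for less inhibition and higher numbers for more inhibition at the one dose given (going by the name of the read-out)), compound 1 gives 15.9%. Measured the same way, compound 2 gives 15.9%, so the step of no change at the digits printed from compound 1 to compound 2 (within the scatter) shows that moving the chlorine from one position on the benzyl ring to the other left the read-out where it was.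

Compound 3 `CC1=C(C(=O)Nc2ccc([N+](=O)[O-])cc2)C(c2cccc([N+](=O)[O-])c2)N=C(SCc2ccccc2Cl)N1` carries a different core; how its core differs from that of compound 1 is not broken down here. In this assay compound 3 gives 12.8%, a number that sits close to those of compound 1 and compound 2 and not apart from them.

Compound 4 `CC1=C(C(=O)Nc2ccc([N+](=O)[O-])cc2)C(c2cccc([N+](=O)[O-])c2)N=C(SCc2cccc(Cl)c2)N1` has not yet been measured. It stands to compound 3 exactly as compound 2 stands to compound 1, with the same change at the same place: 3-chlorophenyl in place of 2-chlorophenyl on a saturated chain carbon bound to a sulfur. Going by the values given here, the only guide to what this change does is the pair of compound 1 and compound 2, where the step was flat. On that basis the step from compound 3 to compound 4 is expected to be small, a number 0.2 percentage points higher from compound 3 to compound 4 (within the scatter), because no change at the digits printed from compound 1 to compound 2 (within the scatter) showed no movement for this change on the other core. For compound 4 the expected value is therefore 13%. The range for compound 4 is estimated to run from 4% to 23%, wide enough to hold the ordinary scatter of a single-dose measurement of this kind.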

Compound 4, a percentage reported as inhibition, in the whole organism at one dose (the size of the read-out at that dose, not a potency): 17.9%
Compound 4: the middle estimate sits 4.9 percentage points below what was measured; the range from low to high includes it.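

In this assay, putting 3-chlorobenzyl in place of 2-chlorobenzyl on the second core gives a number 5.1 percentage points higher from compound 3 to compound 4 (within the scatter), so here too the change produces no step larger than repeat measurements of this kind would. Set beside the first core, the two steps do not stand apart: the same change on two cores in this assay, no change at the digits printed (within the scatter) from compound 1 to compound 2 and a number 5.1 percentage points higher (within the scatter) from compound 3 to compound 4, 5.1 percentage points apart, within the scatter of two such steps This shows that, as far as this read-out can tell, the change behaved alike on both cores, but it rests on only two pairs of compounds at one dose and one time point, so it does not show that the two cores respond identically, since a real but small difference could hide within the scatter, nor does it show that the same would hold on any other core.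

All the compounds shown keep a chlorine on the benzyl ring, so it remains open whether the read-out would move if that chlorine gave way to another group, such as a methoxy group or a nitrile. From the compounds shown here alone, it is also open what a different group on the sulfur, such as a longer alkyl chain or a chain ending in an amine, would do to the read-out on either core.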